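Inverting one chain stereocentre of compound 1

This account rests on a few compounds, and the source may have more. Where it says the series, first, only, none or still open, it means among the compounds named here.

Measured values in a functional assay on the whole organism (stomach) with Rattus norvegicus as the target (on this read-out higher numbers stand for an effect only at larger amounts of compound and lower numbers for an effect already at smaller amounts), for this series
- compound 1 `CCCC[C@@](C)(OC)[C@H](O)/C=C/C1[C@H](O)C[C@H](O)[C@@H]1C/C=C\CCCC(=O)OC` gives 1.5 mg/kg
- compound 2 `CCCC[C@](C)(OC)[C@H](O)/C=C/C1[C@H](O)CC(=O)[C@@H]1C/C=C\CCCC(=O)OC` gives 0.5 mg/kg

Of these two numbers, compound 1 has the higher, and the number for compound 2 lies lower by more than the usual scatter. The next compound to be read is compound 3 `CCCC[C@@](C)(OC)[C@@H](O)/C=C/C1[C@H](O)C[C@H](O)[C@@H]1C/C=C\CCCC(=O)OC` which keeps the atoms and bonds of compound 1. Against compound 1 it shows the two compounds have the same atoms and bonds; at least one stereo element is drawn with a configuration in one of them and without one in the other: 1 of 8 stereo elements differ; a stereocentre at a saturated chain carbon is drawn R in compound 1 and S in compound 3 so a stereocentre at a saturated chain carbon is drawn R in compound 1 and S in compound 3.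

Among the compounds with values here, no measured pair isolates such an inversion, so the expectation rests on the structural change alone. A step toward a higher number, beyond the scatter, is expected in this assay for this inversion. The estimated step is a 4.0-fold higher number from compound 1 to compound 3 (0.60 log units; beyond the scatter) in that direction. For compound 3 the expected value is 6 mg/kg with an estimated range from 1.5 mg/kg to 25 mg/kg as a deliberately wide margin.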

Compound 3, dose for 50% inhibition: > 2 mg/kg
Compound 3: only a limit was reported; the forecaster's own chance of this, stated with the estimate: 15%; the middle value is on the limit's open side.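

In this assay compound 3 is reported only as a limit, > 2 mg/kg. Inverting the stereocentre at a saturated chain carbon from R to S gives an at least 1.3-fold higher number from compound 1 to compound 3 (0.12 log units; that floor lies within the scatter), which is the first reading at this position and sets only a floor, so the data do not establish that the inversion changes the dose at all. The comparison is restricted further by two features of the data: the limit of > 2 mg/kg in this assay, at which 1 of the 3 values shown sits, and, in addition, the fact that one of compounds 1 and 3 is drawn with a defined configuration and the other without, at the place where they differ

The compounds shown leave open the true size of this step and whether the same inversion gives a similar result in the carbonyl-bearing compound 2. Also open, from the compounds shown here alone, is what an amine at this chain carbon would give in this assay.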